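Swapping the pyridine substituent on a camphor-sulfonyl piperazine

The compounds below may be only part of what the source reports. "The series", "measured", "known", "first", "only" and "open" are said of these compounds alone.

Compound 1 `CC1(C)[C@@H]2CC[C@@]1(CS(=O)(=O)N1CCN(c3ncccc3C(F)(F)F)CC1)C(=O)C2` gives > 31600 nM
Compound 2 `CC1CN(c2ccc(C(F)(F)F)cn2)CCN1S(=O)(=O)C[C@]12CC[C@H](CC1=O)C2(C)C` gives 631 nM

Both compounds were tested in a functional assay on CHO-K1 cells for antagonist activity at C-X-C chemokine receptor type 3 (Homo sapiens), read by FLIPR and calcium flux; on this read-out lower numbers stand for stronger inhibition and higher numbers for weaker inhibition. Compound 1 returns only a limit of the assay, > 31600 nM, so its true value is not pinned down. Its position is told by the limit of > 31600 nM in this assay, at which 1 of the 2 values shown sits. Compound 2 differs from compound 1 in more than one place; in this assay compound 2 gives a measured number, 631 nM. Within the data shown here, no single-change step between measured compounds exists here, so nothing can yet be said about the weight of any one change.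

Compound 3 `CC1(C)[C@@H]2CC[C@@]1(CS(=O)(=O)N1CCN(c3ccc([N+](=O)[O-])cn3)CC1)C(=O)C2` is the next compound to be measured. It differs from compound 1 by 5-nitropyridin-2-yl in place of 3-(trifluoromethyl)pyridin-2-yl on an amine nitrogen in a ring. Because compound 1 sits at the limit (the limit of > 31600 nM in this assay, at which 1 of the 2 values shown sits), any reading for compound 3 can only reveal a gain or no change. The expectation for compound 3 is a modest gain, an at least 5.2-fold lower number from compound 1 to compound 3 (0.72 log units; beyond the scatter), with wide uncertainty. The estimate for compound 3 is 6000 nM, expected between 600 nM and 31600 nM.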

Compound 3, half-maximal inhibitory concentration: > 31600 nM
Compound 3 ended at the assay's limit; the forecaster's own chance of this, stated with the estimate: 40%; middle value at least 5.2-fold (0.72 log units) away from the limit.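

Compound 1 and compound 3 both end at a limit rather than a number, so no step between them can be read: the limit of > 31600 nM in this assay, at which 2 of the 3 values shown sit.

Going by these compounds, how strongly either compound truly inhibits stays open, as does whether 5-nitropyridin-2-yl and 3-(trifluoromethyl)pyridin-2-yl differ at all on the shared core.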